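Compound 4 Against the Aryl Changes Seen So Far

The compounds below may be only part of what the source reports. "The series", "measured", "known", "first", "only" and "open" are said of these compounds alone.

Of the compounds shown here, three sharing one core have been measured in a functional assay on Ehrlich cells (Mus musculus) for cytotoxicity, tested at 100 ug/mL; on this read-out lower numbers stand for a weaker effect and higher numbers for a stronger effect at the one concentration tested. Compound 1 `COc1cc(N2C(N)=C(C#N)C(c3ccc([N+](=O)[O-])cc3)C3=C2CC(C)(C)CC3=O)cc(OC)c1OC` gives 80%. Compound 2 `COc1cc(N2C(N)=C(C#N)C(c3c(OC)ccc4ccccc34)C3=C2CC(C)(C)CC3=O)cc(OC)c1OC` gives 30%, and compound 3 `COc1cc(N2C(N)=C(C#N)C(c3c(O)ccc4ccccc34)C3=C2CC(C)(C)CC3=O)cc(OC)c1OC` gives 90%, the highest of the three numbers, though its gap to compound 1 lies within the scatter. The large steps were a number 50 percentage points lower from compound 1 to compound 2 (beyond the scatter) and a number 60 percentage points higher from compound 2 to compound 3 (beyond the scatter). Compound 4 `COc1cc(N2C(N)=C(C#N)C(c3cccc([N+](=O)[O-])c3)C3=C2CC(C)(C)CC3=O)cc(OC)c1OC` is not yet measured; it differs from compound 3 by 3-nitrophenyl in place of 2-hydroxynaphthalen-1-yl on a saturated ring carbon. Compound 1 carries 4-nitrophenyl on a saturated ring carbon, so the step of a number 10 percentage points higher from compound 1 to compound 3 (within the scatter) bears most directly on this change. Compound 4 is therefore expected to show a number 15 percentage points lower from compound 3 to compound 4 (beyond the scatter), a step not beyond the scatter. The estimate for compound 4 is 75%, within 50% to 95%.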

Compound 4, a percentage reported as activity, at one concentration (the size of the read-out at that concentration, not a potency): 30%
Estimate against measurement, compound 4: 45 percentage points above, outside the stated range (below it).
By their numbers in this assay, from the lowest: compounds 2 and 4 (each within the scatter of the next); then compounds 1 and 3 (each within the scatter of the next).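

Within the nitrophenyl pair, the position of the nitro group matters in this assay: with 3-nitrophenyl in place of 4-nitrophenyl, the result is a number 50 percentage points lower from compound 1 to compound 4 (beyond the scatter). Replacing 2-hydroxynaphthalen-1-yl with 3-nitrophenyl gives a number 60 percentage points lower from compound 3 to compound 4 (beyond the scatter), whereas replacing 2-methoxynaphthalen-1-yl with it gives no change at the digits printed from compound 2 to compound 4 (within the scatter), so a naphthalene is not required for either the high or the low numbers seen here. No measurement available here accounts for these differences. The compounds shown leave open how an amine or a carboxylic acid in place of the nitro group on this phenyl ring would read out.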